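Notes on the step from compound 2 to compound 3

This account rests on a few compounds, and the source may have more. Where it says the series, first, only, none or still open, it means among the compounds named here.

- compound 1 `O=C(Nc1ccccn1)c1cccc(Nc2ncc(F)c(Nc3ccc(F)cc3)n2)c1` gives 15100 nM
- compound 2 `CN1CCC(C(=O)Nc2cccc(Nc3ncc(F)c(Nc4ccc(F)cc4)n3)c2)CC1` gives 1150 nM

In a functional assay on DU-145 cells (Homo sapiens) for antiproliferative activity, read by sulforhodamine B assay, with a stated time of 3 days (a higher number here means a weaker inhibitor of growth, a lower number a stronger inhibitor of growth), compound 2 holds the lower of the two numbers (1150 nM). Compound 3 `O=C(Nc1cc(Cl)cc(Cl)c1)c1cccc(Nc2ncc(F)c(Nc3ccc(F)cc3)n2)c1` differs from it as follows: (3,5-dichlorophenyl)carbamoyl in place of ((1-methylpiperidin-4-yl)carbonyl)amino on an aromatic carbon and the change sits on an aromatic carbon of a six-membered aromatic ring of carbon only, meta to a large group. For the measured compounds named here, the one measured step bearing on this is large: a 13-fold lower number from compound 1 to compound 2 (1.12 log units; beyond the scatter) with ((1-methylpiperidin-4-yl)carbonyl)amino in place of (pyridin-2-yl)carbamoyl. Compound 3 gives that group up again and carries a carbamoyl, as compound 1 (15100 nM) does, so a large move to a higher number is expected in this assay, perhaps somewhat smaller than that step. The (3,5-dichlorophenyl)carbamoyl group itself has no measured value, so the uncertainty is wide. The expected step is a 6.1-fold higher number from compound 2 to compound 3 (0.78 log units; beyond the scatter) on this reading. For compound 3 the estimate is 7000 nM, within an expected range of 2000 nM to 25000 nM.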

Compound 3, concentration for 50% growth inhibition: 17500 nM
The estimate for compound 3 lay 2.5-fold (0.40 log units) below the measured number; low and high end bracket the measured number.
By their numbers in this assay, from the lowest: compound 2; then compounds 1 and 3 (each within the scatter of the next).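

Replacing ((1-methylpiperidin-4-yl)carbonyl)amino with (3,5-dichlorophenyl)carbamoyl on this aromatic carbon gives a 15-fold higher number from compound 2 to compound 3 (1.18 log units; beyond the scatter) in this assay and loses the gain held by compound 2. Within the carbamoyl pair, 3,5-dichlorophenyl in place of pyridin-2-yl on the amide-type nitrogen gives a 1.2-fold higher number from compound 1 to compound 3 (0.06 log units; within the scatter) and so does not separate these two aromatic groups. Of the three, only compound 2 carries ((1-methylpiperidin-4-yl)carbonyl)amino, and only compound 2 stands beyond the scatter of the other two.

No evidence at hand accounts for these steps. Still open, from the compounds shown here alone, is whether the gain depends on the piperidine ring nitrogen, its methyl group or the direction of the amide link, which a cyclohexylcarbonylamino group, a piperidin-4-ylcarbonylamino group or a (1-methylpiperidin-4-yl)carbamoyl group could separate.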